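Hydroxynaphthyl in Place of Methylphenyl on Ehrlich Cells

A few compounds are considered here, and "the series" means these few. Any claim that something is new, unique, unknown or untested is made for them only; others in the source may bear on it.

Compound 1 `Cc1ccc(C2C(C#N)=C(N)N(c3ccc(S(N)(=O)=O)cc3)C3=C2CCCC3)cc1` gives 20%.
Compound 2 `N#CC1=C(N)N(c2ccc(S(N)(=O)=O)cc2)C2=C(CCCC2)C1c1ccc(O)cc1` gives 20%.
Compound 3 `N#CC1=C(N)N(c2ccc(S(N)(=O)=O)cc2)C2=C(CCCC2)C1c1ccc([N+](=O)[O-])cc1` gives 0%.

These three compounds share one core and differ only in the aromatic group on a saturated ring carbon. In a functional assay on Ehrlich cells (Mus musculus) for cytotoxicity, read by trypan blue exclusion, with a stated time of 2 h, tested at 10 ug/mL (on this read-out higher numbers stand for a stronger effect at the one concentration tested and lower numbers for a weaker effect), compound 1 stands level with compound 2 at the digits shown, and the two together are the highest of the three numbers. The step of no change at the digits printed from compound 1 to compound 2 (within the scatter) shows that hydroxy in place of methyl leaves the read-out unchanged, while a number 20 percentage points lower from compound 1 to compound 3 (beyond the scatter) and a number 20 percentage points lower from compound 2 to compound 3 (beyond the scatter) show that nitro lowers it.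

Compound 4 `N#CC1=C(N)N(c2ccc(S(N)(=O)=O)cc2)C2=C(CCCC2)C1c1c(O)ccc2ccccc12` differs from compound 1 in one place: 2-hydroxynaphthalen-1-yl in place of 4-methylphenyl on a saturated ring carbon. Within the data shown here, the only measured step that bears on this is no change at the digits printed from compound 1 to compound 2 (within the scatter), since it too brings a hydroxy group onto the aromatic ring, and it was within the scatter. Among the measured compounds shown here, no measured step adds a second aromatic ring, so that part of the change has no precedent here. The step of no change at the digits printed from compound 1 to compound 4 (within the scatter) is therefore expected to stay within the scatter. Compound 4 is estimated at 20%, with a range from 0% to 40%.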

Compound 4, a percentage reported as activity, at one concentration (the size of the read-out at that concentration, not a potency): 10%
Estimate against measurement, compound 4: 10 percentage points above; the range from low to high includes it.
By their numbers in this assay, from the lowest: compounds 3, 4, 1 and 2 (each within the scatter of the next, the first and the last beyond it).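

In this assay, placing 2-hydroxynaphthalen-1-yl on this saturated ring carbon gives a number 10 percentage points lower from compound 1 to compound 4 (within the scatter) and a number 10 percentage points lower from compound 2 to compound 4 (within the scatter), so a group with a second aromatic ring does not separate compound 4 from either compound. The comparison with the nitro compound gives a number 10 percentage points higher from compound 3 to compound 4 (within the scatter), so compound 4 cannot be separated from compound 3 either, even though compound 3 lies beyond the scatter of compounds 1 and 2. Compound 4 therefore falls in the gap between them and belongs clearly to neither side. No measurement here explains these readings.

The compounds shown leave open what the hydroxy group contributes on the naphthalene, which plain naphthalen-1-yl would address. They also leave open how an amine or a carboxylic acid on the phenyl ring would read at this position.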